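A few compounds are considered here, and "the series" means these few. Any claim that something is new, unique, unknown or untested is made for them only; others in the source may bear on it.

Compound 1 `COc1ccc(C(O)(Cc2ccc(C)cc2)c2cccc3ccccc23)c(OC)c1OC`: > 20000 nM
Compound 2 `COc1ccc(C(c2ccc(OCCO)cc2)c2cccc3ccccc23)c(OC)c1OC`: > 20000 nM
Compound 3 `COc1ccc(C(c2ccccc2O)c2cccc3ccccc23)c(OC)c1OC`: > 20000 nM

These readings come from a functional assay on HCT-116 cells (Homo sapiens) for inhibition, read by sulforhodamine B assay, with a stated time of 48 h (a higher number here means a weaker inhibitor, a lower number a stronger inhibitor), and each is a limit of the assay, not a number. Compound 3 therefore stands only at its limit of > 20000 nM. All the measured compounds share one result: the limit of > 20000 nM in this assay, at which 3 of the 3 values shown sit.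

Compound 4 `C=CCOC(c1ccc(OC)c(OC)c1OC)c1cccc2ccccc12` differs from compound 3 at a saturated chain carbon bound to two aromatic carbons: allyloxy in place of 2-hydroxyphenyl on a saturated chain carbon bound to two aromatic carbons. For the measured compounds named here, the one measured step at this place, a step that the two limits leave unreadable from compound 2 to compound 3, has no readable size. No measured step sizes this change, so no shift beyond the scatter is expected. The expected step is a step that the limit leaves unreadable from compound 3 to compound 4. For compound 4 the estimate is 22000 nM, with an expected range of 9000 nM to 45000 nM.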

Compound 4, half-maximal inhibitory concentration: > 20000 nM
Compound 4 was reported as a limit (the forecaster's own chance of this, stated with the estimate: 75%); the middle value does not contradict the limit.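

Compound 4 is likewise reported only as a limit, so its steps from compound 2 and from compound 3 cannot be read: the limit of > 20000 nM in this assay, at which 4 of the 4 values shown sit.

The compounds shown leave open which change to the shared core, if any, would give a measurable value in this assay.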